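This account rests on a few compounds, and the source may have more. Where it says the series, first, only, none or still open, it means among the compounds named here.

Compound 1 `CC1=CC[C@H](C(C)(C)NC(=S)NN)CC1` carries the shared core with nothing attached to its terminal nitrogen. In a functional assay on NCI-H460 cells (Homo sapiens) for inhibition, read by sulforhodamine B assay, with a stated time of 48 h (on this read-out lower numbers stand for stronger inhibition of growth and higher numbers for weaker inhibition of growth), compound 1 reaches only a limit of the assay, > 100000 nM. Compound 2 `CC1=CC[C@H](C(C)(C)NC(=S)N/N=C/c2ccc(O)cc2)CC1` likewise gives only a limit in this assay, > 100000 nM. For the measured compounds named here, compound 3 `CC1=CC[C@H](C(C)(C)NC(=S)N/N=C/c2ccccc2Cl)CC1` is the one member with an actual number, 81000 nM in this assay. The remaining two values shown are the limit of > 100000 nM in this assay, at which 2 of the 3 values shown sit. Going by the values given here, the single step between measured neighbours, an at least 1.2-fold lower number from compound 2 to compound 3 (0.09 log units; that floor lies within the scatter), only reaches a floor that sits within the usual scatter, so it shows no clear change. Compound 4 `CC1=CC[C@H](C(C)(C)NC(=S)N/N=C/c2ccc[nH]2)CC1` is not yet measured; it differs from compound 3 by 1H-pyrrol-2-yl in place of 2-chlorophenyl on a carbon with a double bond to nitrogen. Among the compounds with values here, no measured step exchanges a six-membered aromatic ring of carbon only for a five-membered aromatic ring with one hetero atom, so the only guide is that every measured compound is weak. On that basis compound 4 is expected to stay weak, with the step of a 1.2-fold higher number from compound 3 to compound 4 (0.09 log units; within the scatter) remaining within the scatter. In this assay compound 4 is estimated at 100000 nM, within a range from 40000 nM to 250000 nM, and a limit rather than a number is quite possible.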

Compound 4, concentration for total growth inhibition: 57500 nM
Beside the measured number, compound 4's estimate is 1.7-fold (0.24 log units) above it; the range from low to high includes it.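

With a second actual number in this assay, this place on a carbon with a double bond to nitrogen now has its first step between two real values, and exchanging the six-membered aromatic ring of carbon only for a five-membered aromatic ring with 1 hetero atom gives a 1.4-fold lower number from compound 3 to compound 4 (0.15 log units; within the scatter). The two other new steps, an at least 1.7-fold lower number from compound 2 to compound 4 (0.24 log units; that floor lies within the scatter) and an at least 1.7-fold lower number from compound 1 to compound 4 (0.24 log units; that floor lies within the scatter), are floors that also lie within the scatter. They give only floors because compound 1 and compound 2 are not numbers but limits: the limit of > 100000 nM in this assay, at which 2 of the 4 values shown sit.

So no group shown here clearly separates from another in this assay. Still open, on these data alone, is whether a furan or thiophene ring, an amine, a carboxylic acid or a longer carbon chain in this place would move the number beyond the scatter.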